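The source may report more compounds than this note shows. Statements on the series, on what has been measured and on what is new or still open speak of the compounds shown alone.

Compound 1 `Nc1scc(CN2CCN(c3cccc4ccccc34)CC2)c1C(=O)c1ccc(Cl)cc1`: 0%
Compound 2 `Nc1scc(CN2CCN(c3cccc(F)c3)CC2)c1C(=O)c1ccc(Cl)cc1`: 4%

In an assay on CHO cells for displacement of a labelled ligand from adenosine receptor A3 (Homo sapiens), read by scintillation counting, with a stated time of 120 min, tested at 10 uM (a lower number here means less inhibition, a higher number more inhibition at the concentration tested (going by the name of the read-out)), compound 2 gives 4%, the higher of the two numbers, though a number 4 percentage points higher from compound 1 to compound 2 (within the scatter), so compound 1 and compound 2 show the same thing: hardly any inhibition. Compound 3 `Nc1scc(CN2CCN(c3ccc(Cl)c(Cl)c3)CC2)c1C(=O)c1ccc(Cl)cc1` differs from compound 2 in one place: 3,4-dichlorophenyl in place of 3-fluorophenyl on an amine nitrogen in a ring. Within the data shown here, the only measured step exchanges the group on the same ring nitrogen and stays within the scatter. Compound 3 is therefore expected to move by a number 1 percentage points higher from compound 2 to compound 3 (within the scatter), nothing beyond the scatter, and the estimate for compound 3 is 5%, ranging from -10% to 25%.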

Compound 3, a percentage reported as inhibition, at one concentration (the size of the read-out at that concentration, not a potency): 3%
Compound 3: the middle estimate sits 2 percentage points above what was measured, within the range that was stated.
By their numbers in this assay, from the lowest: compounds 1, 3 and 2 (each within the scatter of the next).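

Replacing 3-fluorophenyl with 3,4-dichlorophenyl on this ring nitrogen leaves the reading in this assay unmoved (a number 1 percentage points lower from compound 2 to compound 3 (within the scatter)), and replacing naphthalen-1-yl with it does the same (a number 3 percentage points higher from compound 1 to compound 3 (within the scatter)). All three aromatic groups at this position now give the same near-absent inhibition, so adding a second halogen to the phenyl ring shows no effect here. Nothing measured here accounts for this flat result.

From the compounds shown here alone, it stays open whether a benzyl group or a longer alkyl chain on this nitrogen would give any inhibition. An amine or carboxylic acid on the phenyl ring is equally untested among these compounds.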